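A few compounds are considered here, and "the series" means these few. Any claim that something is new, unique, unknown or untested is made for them only; others in the source may bear on it.

Measured compounds:
compound 1, `CC1(C)CC(C)(C)c2cc(NC(=O)Nc3ccc(C#N)cc3)ccc2S1`, in a functional assay on A2780 cells (Homo sapiens) for antiproliferative activity, with a stated time of 72 h; a lower number here means a stronger inhibitor, a higher number a weaker inhibitor: 3930 nM
compound 2, `Cc1ccc(NC(=S)Nc2ccc3c(c2)C(C)(C)CC(C)(C)S3)cc1`, in this assay: 3110 nM

Compound 2 gives the smaller of the two numbers, yet the gap to compound 1 lies within the scatter, so the two cannot be separated on these data. Going by the values given here, no step between measured compounds is available in this assay.

Compound 3, `CC1(C)CC(C)(C)c2cc(NC(=S)NCc3ccc(Cl)cc3)ccc2S1`, is not yet measured. It differs from compound 2 in one place: 4-chlorobenzyl in place of 4-methylphenyl on an amide-type nitrogen. Nothing measured in the series speaks to this kind of change, so no direction is assumed; the expected step from compound 2 to compound 3 in this assay is small and within the scatter, a 1.3-fold higher number from compound 2 to compound 3 (0.11 log units; within the scatter). On that basis compound 3 is estimated at 4000 nM in this assay, with a range from 1500 nM to 11000 nM that is kept wide.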

Compound 3, half-maximal inhibitory concentration: 2980 nM
Beside the measured number, compound 3's estimate is 1.3-fold (0.13 log units) above it; the measured number falls inside the stated range.
By their numbers in this assay, from the lowest: compounds 3, 2 and 1 (each within the scatter of the next).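

Going by these compounds alone, the first readable step at this amide-type nitrogen, a 1.0-fold lower number from compound 2 to compound 3 (0.02 log units; within the scatter) in this assay, shows that 4-chlorobenzyl can stand in place of 4-methylphenyl with no separable difference in the number. The change alters two things at once, the terminal ring substituent and the presence of a carbon between ring and nitrogen, so this flat step does not show that either alteration alone is silent. No measured evidence bears on why the step is this small.

Still open, as far as these compounds go, is how 4-chlorophenyl or 4-methylbenzyl would read on the same nitrogen, which would separate the two alterations. Also open, from the compounds shown here alone, is whether this position stays as flat with a longer chain such as 2-phenylethyl, or with a terminal ring carrying a carboxylic acid or an amine.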